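This account rests on a few compounds, and the source may have more. Where it says the series, first, only, none or still open, it means among the compounds named here.

Measured so far:
- compound 1, `COc1cc(Cl)cc(-c2nn(-c3cccc(NC(=O)Nc4ccc(Cl)c(C(F)(F)F)c4)c3)cc2-c2ccncc2)c1`: 23.6%
- compound 2, `COc1cc(Cl)cc(-c2nn(-c3cccc(NC(=O)c4cc(C(F)(F)F)cc(C(F)(F)F)c4)c3)cc2-c2ccncc2)c1`: 78.8%

Both compounds were run in a functional assay on SK-MEL-28 cells (Homo sapiens) for inhibition, read by sulforhodamine B assay, with a stated time of 48 h, tested at 10 uM; on this read-out higher numbers stand for a weaker effect at the one concentration tested and lower numbers for a stronger effect. On this read-out compound 1 gives 23.6%, the lowest of the two numbers and therefore the stronger effect of the pair. Compound 2 gives 78.8%, a number well beyond the scatter above that of compound 1. Among the measured compounds shown here, no step between two compounds differing in one place is available in this set, so the two values show only that compound 1 is the more effective of the pair.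

The unmeasured compound 3, `COc1cc(Cl)cc(-c2nn(-c3cccc(NC(=O)Nc4ccc(Cl)c(Cl)c4)c3)cc2-c2ccncc2)c1`, is built on compound 1 and differs from it in one place: chloro in place of trifluoromethyl on an aromatic carbon. The urea and the rest of the shared core are unchanged.

For the measured compounds named here, with no single-point step to lean on, the expectation rests on the small size of the change alone. In this assay the step from compound 1 to compound 3 is expected to be small, most likely within the scatter, perhaps a slight weakening. The estimate for compound 3 is 30%, within 15% to 55%, corresponding to an expected step of a number 6.4 percentage points higher from compound 1 to compound 3 (within the scatter).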

Compound 3, a percentage reported as activity, at one concentration (the size of the read-out at that concentration, not a potency): 23.2%
For compound 3 the middle estimate is 6.8 percentage points above the measured one; the range from low to high includes it.
By their numbers in this assay, from the lowest: compounds 3 and 1 (each within the scatter of the next); then compound 2.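

Chloro in place of trifluoromethyl, on an aromatic carbon ortho to a chloro group and meta to a large group, gives a number 0.4 percentage points lower from compound 1 to compound 3 (within the scatter) in this assay and leaves the two compounds indistinguishable on this read-out. This position therefore accepts a group of 1 heavy atom in place of one of 4 heavy atoms, and within this pair the fluorine atoms are not needed to keep the level of effect seen with compound 1. No supporting data are available to explain this equivalence.

Going by these compounds, it remains open whether any substituent is needed on this carbon: hydrogen, methyl, methoxy or nitrile in the same place would test how far the tolerance extends beyond these two groups. Compound 2 differs from compound 1 and compound 3 in more than one place, so the contributions of the urea and of the substituents on the terminal aromatic ring to its separate level of effect cannot be told apart.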